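A few compounds are considered here, and "the series" means these few. Any claim that something is new, unique, unknown or untested is made for them only; others in the source may bear on it.

Three compounds share one core and were tested in a functional assay, tested at 100 uM; on this read-out lower numbers stand for a weaker effect and higher numbers for a stronger effect at the one concentration tested. Compound 1 `O=C(O)c1cn(Cc2ccc(Cl)cc2)c2ccccc2c1=O` gives 28.7%, compound 2 `O=C(NO)c1cn(Cc2ccc(Cl)cc2)c2ccccc2c1=O` gives 31.7%, and compound 3 `COc1cc(Cn2cc(C(=O)NO)c(=O)c3ccccc32)cc(OC)c1` gives 41.3%. Compound 2 sits close to both neighbours: the gap to compound 1 and the gap to compound 3 each stay within the usual scatter, so none of the three can be called stronger or weaker than another.

Going by the values given here, the only single-point step measured is a number 3 percentage points higher from compound 1 to compound 2 (within the scatter), a change at the carbonyl carbon that lies far from the ring altered in the next compound. Compound 4 `O=C(NO)c1cn(Cc2ccc(O)cc2)c2ccccc2c1=O` is the unmeasured compound; it differs from compound 2 in one place: hydroxy in place of chloro on an aromatic carbon. Among the compounds with values here, no measured step touches this group on the aromatic ring, and compound 3, which carries other groups on that ring, gives a number within the scatter of compound 2. Therefore no step beyond the scatter is expected, and compound 4 is estimated at 33% (range 18% to 50%), which means an expected step of a number 1.3 percentage points higher from compound 2 to compound 4 (within the scatter).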

Compound 4, a percentage reported as activity, at one concentration (the size of the read-out at that concentration, not a potency): 74.9%
For compound 4 the middle estimate is 41.9 percentage points below the measured one; the whole stated range lies below it.
By their numbers in this assay, from the lowest: compounds 1, 2 and 3 (each within the scatter of the next, the first and the last beyond it); then compound 4.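

In this assay the change from 4-chlorophenyl to 4-hydroxyphenyl gives a number 43.2 percentage points higher from compound 2 to compound 4 (beyond the scatter) and so shows that this place on the aromatic ring can move the read-out strongly. The only earlier step between compounds differing in one place, a number 3 percentage points higher from compound 1 to compound 2 (within the scatter), lay at the carbonyl carbon, so this is the first single change shown to have a large effect. Nothing available explains why swapping chloro for hydroxy has this effect.

As far as these compounds go, it remains open whether the rise is specific to hydroxy, or whether an amine or a hydroxymethyl group at the same place would also give it. From the compounds shown here alone, with one concentration per compound, it also remains open how the step would translate into potency.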